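A few compounds are considered here, and "the series" means these few. Any claim that something is new, unique, unknown or untested is made for them only; others in the source may bear on it.

In a functional assay on PC-3 cells (Homo sapiens) for cytotoxicity, read by MTT assay, with a stated time of 72 h (a higher number here means a weaker inhibitor, a lower number a stronger inhibitor), compound 1 `CNC(=O)c1cc(Oc2ccc(C(=O)/C=C/c3ccc(Cl)c(Cl)c3)cc2)ccn1` gives 8260 nM, compound 2 `CNC(=O)c1cc(Oc2ccc(C(=O)/C=C/c3ccc(C#N)cc3)cc2)ccn1` gives 3870 nM, and compound 3 `CNC(=O)c1cc(Oc2ccc(C(=O)/C=C/c3ccccc3)cc2)ccn1` gives 3170 nM. Compound 3 therefore sits level with its nearest neighbour, as a 1.2-fold lower number from compound 2 to compound 3 (0.09 log units; within the scatter) shows, and clear of the 3,4-dichlorophenyl compound, as a 2.6-fold lower number from compound 1 to compound 3 (0.42 log units; beyond the scatter) shows. The same compound also stands apart in a 2.1-fold lower number from compound 1 to compound 2 (0.33 log units; beyond the scatter).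

Compound 4 `CNC(=O)c1cc(Oc2ccc(C(=O)/C=C/c3ccc(F)cc3)cc2)ccn1` brings one change: fluoro in place of hydrogen on an aromatic carbon. Within the data shown here, the closest precedent is the exchange of cyano and hydrogen, where compound 2 at 3870 nM showed no step beyond the scatter. A similarly small result is expected here, with an estimated change of a 1.1-fold higher number from compound 3 to compound 4 (0.04 log units; within the scatter). The estimated value for compound 4 is 3500 nM, with an expected range of 1800 nM to 7000 nM.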

Compound 4, half-maximal inhibitory concentration: 6140 nM
Compound 4: the middle estimate sits 1.8-fold (0.24 log units) below what was measured; the range from low to high includes it.
By their numbers in this assay, from the lowest: compounds 3, 2, 4 and 1 (each within the scatter of the next, the first and the last beyond it).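

At this aromatic carbon, para to a large group, fluoro gives steps that all stay within the scatter in this assay: a 1.9-fold higher number from compound 3 to compound 4 (0.29 log units; within the scatter), a 1.6-fold higher number from compound 2 to compound 4 (0.20 log units; within the scatter) and a 1.3-fold lower number from compound 1 to compound 4 (0.13 log units; within the scatter). Compound 4 therefore cannot be separated from any of the other three compounds, although compound 1 and compound 3 are separated from each other. Nothing available explains these numbers. Still open, as far as these compounds go, is how a methoxy group or an amine on this same carbon would read in this assay.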